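Swapping the amide substituent on a shared dihydrofuran amide core

The source may hold more compounds than are shown below. What is called first, only, known or untested is meant among the compounds shown, and "the series" means these compounds.

Compound 1 `C=CC1=C(C(=O)Nc2ccc(OCC)cc2)C(c2ccc(OC)cc2)OC1` carries a 4-ethoxyphenyl group on its amide nitrogen. In a functional assay on A549 cells (Homo sapiens) for cytotoxicity, read by MTT assay, with a stated time of 24 h (on this read-out higher numbers stand for weaker inhibition and lower numbers for stronger inhibition), compound 1 gives 17600 nM, the only numerical result among the three measured compounds. Compound 2 `C=CC1=C(C(=O)NC(C)(C)C)C(c2ccc(F)cc2)OC1` carries a tert-butyl group on the amide nitrogen. In this assay compound 2 reaches only a limit of the assay, > 100000 nM, not a number. Compound 3 `C=CC1=C(C(=O)Nc2ccccc2)C(c2ccc(F)cc2)OC1` carries a phenyl group there instead. In this assay compound 3 likewise reaches only a limit, > 100000 nM. The step that the two limits leave unreadable from compound 2 to compound 3 cannot be read; the limit of > 100000 nM in this assay, at which 2 of the 3 values shown sit, is all that either compound shows.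

Compound 4 `C=CC1=C(C(=O)NCc2ccc(Cl)cc2)C(c2ccc(OC)cc2)OC1` is not yet measured. It differs from compound 1 by 4-chlorobenzyl in place of 4-ethoxyphenyl on an amide-type nitrogen. For the measured compounds named here, no measured step covers this exchange: the single step available, a step that the two limits leave unreadable from compound 2 to compound 3, has no readable size and concerns a different pair of groups. The expectation for this assay is therefore no step beyond the usual scatter in either direction, with wide uncertainty around that. Compound 4 is estimated at 30000 nM, with a range from 8000 nM to 100000 nM. This estimate means an expected step of a 1.7-fold higher number from compound 1 to compound 4 (0.23 log units; within the scatter), resting on the value of compound 1 alone.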

Compound 4, half-maximal inhibitory concentration: > 100000 nM
Compound 4: a limit, no number (the forecaster's own chance of this, stated with the estimate: 40%); middle value at least 3.3-fold (0.52 log units) from the limit.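

For the compounds shown here, on the amide nitrogen of the core of compound 1, the exchange of 4-ethoxyphenyl for 4-chlorobenzyl gives the first readable step at this position, and in this assay it is an at least 5.6-fold higher number from compound 1 to compound 4 (0.75 log units; beyond the scatter). Compound 4 gives > 100000 nM, which is a limit of the assay and not a number, so this step has a known minimum size but no known full size, and it shows that the measurable effect of compound 1 on these cells does not survive this change on the amide nitrogen. The finding remains a thin one, since compound 1 is still the only compound with a number to compare against: the limit of > 100000 nM in this assay, at which 3 of the 4 values shown sit.

The exchange alters the group in two ways at once, swapping ethoxy for chlorine on the ring and setting a carbon link between the ring and the nitrogen, so the compounds shown cannot tell which of the two matters. A 4-chlorophenyl or a 4-ethoxybenzyl group on this nitrogen would separate the two, while a chain ending in an amine or a carboxylic acid there remains an open question too.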